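Shortening a Chain Beside the Ketone in Two Cores

This account rests on a few compounds, and the source may have more. Where it says the series, first, only, none or still open, it means among the compounds named here.

Compound 1 `C=C(CC)C(=O)c1ccc(OCc2nc(-c3ccc(C(F)(F)F)cc3)cs2)c(C)c1C` and compound 2 `C=C(C)C(=O)c1ccc(OCc2nc(-c3ccc(C(F)(F)F)cc3)cs2)c(C)c1C` share one core and differ only by hydrogen in place of methyl on a saturated chain carbon bound to a double-bonded chain carbon. In an assay on HL-60 cells for inhibition of glutathione S-transferase P (Homo sapiens), read by spectrophotometry, tested at 5 uM (a lower number here means less inhibition, a higher number more inhibition at the concentration tested (going by the name of the read-out)), compound 1 gives 0%, and compound 2 gives 3.6%, so the step of a number 3.6 percentage points higher from compound 1 to compound 2 (within the scatter) is small. Compound 3 `C=C(CC)C(=O)c1ccc(OCc2nc(-c3ccc4ccccc4c3)cs2)cc1Cl` carries a different core; how its core differs from that of compound 1 is not broken down here. In this assay compound 3 gives 9.5%, which sits within the scatter of both compound 1 and compound 2. Compound 4 `C=C(C)C(=O)c1ccc(OCc2nc(-c3ccc4ccccc4c3)cs2)cc1Cl` is not yet measured and differs from compound 3 by hydrogen in place of methyl on a saturated chain carbon bound to a double-bonded chain carbon, the same change seen between compound 1 and compound 2. The step of a number 2.5 percentage points higher from compound 3 to compound 4 (within the scatter) is expected to be small because the same change gave a number 3.6 percentage points higher from compound 1 to compound 2 (within the scatter). In this assay compound 4 is therefore estimated at 12%, between 0% and 25%.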

Compound 4, a percentage reported as inhibition, at one concentration (the size of the read-out at that concentration, not a potency): 55.2%
Compound 4: the middle estimate sits 43.2 percentage points below what was measured; measured number above the stated range.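

In this assay, going from ethyl to methyl at this place gives a number 45.7 percentage points higher from compound 3 to compound 4 (beyond the scatter). Set beside the earlier step, this shows that the same change does not carry over at one size from one core to the other: the same change on two cores in this assay, a number 3.6 percentage points higher (within the scatter) from compound 1 to compound 2 and a number 45.7 percentage points higher (beyond the scatter) from compound 3 to compound 4, 42.1 percentage points apart, beyond the scatter of two such steps With only two pairs, the data do not show which feature of the cores matters or why the steps differ, and each number is a reading at one concentration, not a potency.

The compounds shown leave open how a longer chain, such as propyl, would read at this place on either core. They also leave open what the change would do on a core carrying only some of the features that set these two cores apart.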